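The source may hold more compounds than are shown below. What is called first, only, known or untested is meant among the compounds shown, and "the series" means these compounds.

Of the compounds shown here, three that share one core have been measured in an assay on cells for agonist activity at probable G-protein coupled receptor 34 (Mus musculus), with a stated time of 1 h; a lower number here means a smaller maximal response, a higher number a larger maximal response. Compound 1 `N[C@@H](COP(=O)(O)OCCCOC(=O)CCc1ccccc1OCc1cccc(Oc2ccccc2)c1)C(=O)O` gives 19.4%. Compound 2 `N[C@@H](COP(=O)(O)OCCCOC(=O)CCc1ccccc1OCc1cccc(Cc2ccccc2)c1)C(=O)O` gives 14.5%. Compound 3 `N[C@@H](COP(=O)(O)OCCCOC(=O)CCc1ccccc1OCc1cccc(Oc2ccc(Br)cc2)c1)C(=O)O` gives 17.7%. Among the compounds with values here, of these three numbers the one for compound 2 is the lowest, yet the step of a number 4.9 percentage points lower from compound 1 to compound 2 (within the scatter) and the step of a number 3.2 percentage points higher from compound 2 to compound 3 (within the scatter) both lie within the scatter, so the three compounds cannot be told apart on this read-out.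

Compound 4 `N[C@@H](COP(=O)(O)OCCCOC(=O)CCc1ccccc1OCc1cccc(Oc2ccc(I)cc2)c1)C(=O)O` has not yet been measured. It differs from compound 2 in a single place: 4-iodophenoxy in place of benzyl on an aromatic carbon. Within the data shown here, two measured steps bear on this change. The step of a number 3.2 percentage points higher from compound 2 to compound 3 (within the scatter) exchanges the same benzyl for 4-bromophenoxy and stays within the scatter; the step of a number 1.7 percentage points lower from compound 1 to compound 3 (within the scatter) puts bromo in place of hydrogen and also stays within the scatter. Iodo in place of bromo has not been tested, but none of the changes seen so far has moved the maximal response beyond the scatter. The expected step is therefore a number 3 percentage points higher from compound 2 to compound 4 (within the scatter), within the scatter. Compound 4 is estimated to give 17.5%, with a range from 10% to 26%.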

Compound 4, largest response reached (Emax), in percent of the reference or control that the assay uses: 19.1%
The estimate for compound 4 lay 1.6 percentage points below the measured number; the range from low to high includes it.
By their numbers in this assay, from the lowest: compounds 2, 3, 4 and 1 (each within the scatter of the next).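

Iodo in place of bromo gives a number 1.4 percentage points higher from compound 3 to compound 4 (within the scatter) in this assay, and iodo in place of hydrogen gives a number 0.3 percentage points lower from compound 1 to compound 4 (within the scatter) on the same read-out, so hydrogen, bromo and iodo on the phenoxy group cannot be told apart here. Exchanging benzyl for 4-iodophenoxy brings in both an oxygen and an iodine at the aromatic carbon meta to a large group, yet this change gives a number 4.6 percentage points higher from compound 2 to compound 4 (within the scatter) and also leaves the maximal response unresolved. All four compounds therefore remain indistinguishable in this assay, and no separate measurement is available to explain why these changes leave so little mark.

From the compounds shown here alone, it remains open whether a group of a different kind on the phenoxy group, such as an amine or a carboxylic acid, would shift the maximal response beyond the scatter. Going by these compounds, it is equally open whether a longer chain in place of the benzyl or phenoxy link would do so.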